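The compounds below may be only part of what the source reports. "The series", "measured", "known", "first", "only" and "open" are said of these compounds alone.

Compound 1 `ClCc1ccccc1Cn1cnc2c(Cl)nc(Cl)nc21` and compound 2 `ClCc1cccc(Cn2cnc3c(Cl)nc(Cl)nc32)c1` are built from the same atoms joined differently, and the difference between their two cores is not broken down here. In a functional assay on NCI-H322M cells (Homo sapiens) for cytotoxicity, read by sulforhodamine B assay, with a stated time of 48 h (a lower number here means a stronger inhibitor of growth, a higher number a weaker inhibitor of growth), compound 1 gives 3270 nM, and compound 2 gives 5120 nM; the two values lie within the usual scatter of one another. Compound 3 `Nc1nc(Cl)c2ncn(Cc3ccccc3CCl)c2n1` shares the core of compound 1 and carries the change (amino in place of chloro on an aromatic carbon). In this assay compound 3 gives 29500 nM, which is a higher number than that of compound 2 and lies beyond the scatter. The step from chloro to amino is measured once: a 9.0-fold higher number from compound 1 to compound 3 (0.96 log units; beyond the scatter).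

Compound 4 `Nc1nc(Cl)c2ncn(Cc3cccc(CCl)c3)c2n1` is still to be measured. It stands to compound 2 as compound 3 stands to compound 1: the change amino in place of chloro on an aromatic carbon is the same change, made on the same kind of position, and only the core around it differs. For the measured compounds named here, since the single measured example of this change gave a 9.0-fold higher number from compound 1 to compound 3 (0.96 log units; beyond the scatter), a step of comparable size is expected in this assay from compound 2 to compound 4, namely an 8.2-fold higher number from compound 2 to compound 4 (0.91 log units; beyond the scatter); this rests on one pair only, so the range is kept wide. Compound 4 is therefore estimated to give 42000 nM in this assay, with the likely span running from 15000 nM to 120000 nM.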

Compound 4, concentration for total growth inhibition: 22400 nM
Compound 4: middle estimate off by 1.9-fold (0.27 log units), on the high side; low and high end bracket the measured number.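

Carried to the second core, amino in place of chloro on an aromatic carbon again gives a weaker inhibitor of growth in this assay with a 4.4-fold higher number from compound 2 to compound 4 (0.64 log units; beyond the scatter) and so the change acts in the same direction on both cores, each step lying beyond the scatter. Set side by side, the two steps cannot be told apart in size, so within this pair of cores the change carries over from one to the other: the same change on two cores in this assay, a 9.0-fold higher number (0.96 log units; beyond the scatter) from compound 1 to compound 3 and a 4.4-fold higher number (0.64 log units; beyond the scatter) from compound 2 to compound 4, 2.1-fold (0.31 log units) apart, within the scatter of two such steps. For the compounds shown here, this rests on only two pairs, which share everything except the difference between their cores, so it does not show that the step would hold on any other core, that its size is exactly the same on these two, or why the change acts as it does.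

The compounds shown leave open how other groups would read in the same place, such as a methylamino, a dimethylamino or a methoxy group, and so whether the step belongs to amino in particular or to the loss of chloro. They also leave open what would follow if the remaining chloro group were replaced, or if the chloromethyl group gave way to a hydroxymethyl group or a longer chain.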